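Working notes on the step from compound 3 to compound 4

A few compounds are considered here, and "the series" means these few. Any claim that something is new, unique, unknown or untested is made for them only; others in the source may bear on it.

Of the compounds shown here, three have been measured in a functional assay on MCF7 cells (Homo sapiens) for cytotoxicity, read by MTT assay, with a stated time of 96 h; on this read-out higher numbers stand for weaker inhibition and lower numbers for stronger inhibition. Compound 1 `COc1cc(C(=O)c2cn(-c3cccc(Br)c3)cc2-c2ccccc2)cc(OC)c1OC` gives 78 nM. Compound 2 `COc1cc(C(=O)c2cn(-c3ccc(N)cc3)cc2-c2ccccc2)cc(OC)c1OC` gives 35 nM. Compound 3 `COc1cc(C(=O)c2cn(-c3ccccc3)cc2-c2ccccc2Cl)cc(OC)c1OC` gives 76 nM. Among the compounds with values here, the one step between measured compounds that differ in a single place is a 2.2-fold lower number from compound 1 to compound 2 (0.35 log units; beyond the scatter), a change on the aromatic nitrogen. Compound 3 stands second highest of the three numbers; its value and that of compound 1 lie within the scatter of each other, while compound 2 sits lower by an amount beyond the scatter.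

Compound 4 `COc1cc(C(=O)c2cn(-c3ccccc3)cc2-c2c(F)cc(F)cc2F)cc(OC)c1OC` has not yet been measured in this assay. It differs from compound 3 by 2,4,6-trifluorophenyl in place of 2-chlorophenyl on an aromatic carbon; the group sits on an aromatic carbon of a five-membered aromatic ring with one nitrogen, next to the ring atom that bears a large group. Within the data shown here, no measured step touches this position: the only step in hand concerns the group on the aromatic nitrogen and says nothing direct about this change. With nothing to anchor a direction, the expected step of a 1.1-fold higher number from compound 3 to compound 4 (0.02 log units; within the scatter) is none beyond the scatter. Compound 4 is therefore estimated at 80 nM, with a range from 35 nM to 180 nM.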

Compound 4, half-maximal inhibitory concentration: 180 nM
Compound 4: the middle estimate sits 2.3-fold (0.35 log units) below what was measured, within the range that was stated.
By their numbers in this assay, from the lowest: compound 2; then compounds 3 and 1 (each within the scatter of the next); then compound 4.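

In this assay this aromatic carbon, two ring bonds from the ring nitrogen, proves responsive to the group it carries: 2,4,6-trifluorophenyl in place of 2-chlorophenyl gives a 2.4-fold higher number from compound 3 to compound 4 (0.37 log units; beyond the scatter) and moves the number towards weaker inhibition. The earlier compounds shown here showed a step beyond the scatter only for a change on the aromatic nitrogen, whereas this first step at the carbon shows that the number also depends on the aryl group here. No measurement in hand bears on why the number rises with this change.

The step removes one chlorine and brings in three fluorines at once, and the compounds shown do not separate the contribution of either, nor do they show whether a single fluorine at the same place would behave like the chlorine or like the trifluorinated group. Also open, on these data alone, are how the position responds to a phenyl group carrying a methoxy group or an amine, and whether the step keeps its direction when the group on the aromatic nitrogen is the 4-aminophenyl of compound 2.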